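Pyridine sulfonamide series: moving the halogen on the pyridine

This account rests on a few compounds, and the source may have more. Where it says the series, first, only, none or still open, it means among the compounds named here.

compound 1 `O=S(=O)(CSc1nnc(Br)n1Cc1ccc(Br)c2ccccc12)Nc1cccnc1` — in an assay on HEK293 cells for inhibition of solute carrier family 22 member 12 (Homo sapiens) (on this read-out lower numbers stand for stronger inhibition and higher numbers for weaker inhibition), compound 1 gives 32 nM
compound 2 `O=S(=O)(CSc1nnc(Br)n1Cc1ccc(Br)c2ccccc12)Nc1ccc(Cl)nc1` — in this assay compound 2 gives 1940 nM
compound 3 `O=S(=O)(CSc1nnc(Br)n1Cc1ccc(Br)c2ccccc12)Nc1ccc(F)nc1` — in this assay compound 3 gives 1550 nM

Compound 3 holds the second highest of the three numbers; compound 2 is nearest and the two lie within the scatter of each other, while compound 1 is furthest, a 48-fold higher number from compound 1 to compound 3 (1.69 log units; beyond the scatter). Compound 4 `O=S(=O)(CSc1nnc(Br)n1Cc1ccc(Br)c2ccccc12)Nc1cnccc1I` carries 4-iodopyridin-3-yl in place of 6-fluoropyridin-3-yl on a sulfonamide nitrogen. Within the data shown here, no measured step moves a halogen from one position on this ring to another. The steps that come closest are a 61-fold higher number from compound 1 to compound 2 (1.78 log units; beyond the scatter) and a 48-fold higher number from compound 1 to compound 3 (1.69 log units; beyond the scatter), both large losses on adding a halogen to the unsubstituted ring, and a 1.3-fold lower number from compound 2 to compound 3 (0.10 log units; within the scatter), which shows the identity of that halogen mattered little. Whether iodine at a different place recovers any of the loss cannot be read from these three compounds. A modest gain is expected for compound 4, a 1.9-fold lower number from compound 3 to compound 4 (0.29 log units; within the scatter), with wide uncertainty. The estimate for compound 4 in this assay is 800 nM, between 150 nM and 4000 nM.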

Compound 4, half-maximal inhibitory concentration: 10600 nM
Estimate against measurement, compound 4: 13-fold (1.12 log units) below; the measured number lies above the stated range.
By their numbers in this assay, from the lowest: compound 1; then compounds 3 and 2 (each within the scatter of the next); then compound 4.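

Replacing 6-fluoropyridin-3-yl with 4-iodopyridin-3-yl on a sulfonamide nitrogen brings no recovery in this assay and gives a 6.8-fold higher number from compound 3 to compound 4 (0.83 log units; beyond the scatter) and, from the chloro compound, a 5.5-fold higher number from compound 2 to compound 4 (0.74 log units; beyond the scatter) as well. All three halogenated rings lose against the unsubstituted one, and 4-iodopyridin-3-yl loses most with a 330-fold higher number from compound 1 to compound 4 (2.52 log units; beyond the scatter) as its step. Nothing available explains this further loss.

The halogen and its place on the ring change together in this step, so their contributions cannot be separated. Going by these compounds, how a methoxy group or an amine on the ring would compare remains open.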